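A few compounds are considered here, and "the series" means these few. Any claim that something is new, unique, unknown or untested is made for them only; others in the source may bear on it.

Two thiosemicarbazones sharing the same amidine-bearing pyridine core have been tested. Compound 1, `N/C(=N\NC(=S)N1CCCCCC1)c1ccccn1`, carries a seven-membered saturated ring on the thiourea nitrogen, whereas compound 2, `N/C(=N\NC(=S)N1CCOCC1)c1ccccn1`, carries a morpholine there. In a functional assay on MCF7 cells (Homo sapiens) for cytotoxicity, read by MTT assay, with a stated time of 72 h, tested at 1 uM (a lower number here means less inhibition of growth, a higher number more inhibition of growth at the concentration tested), compound 1 gives 25.3%, the higher of the two numbers recorded. In this assay compound 2 gives 14.7%, a number that lies beyond the scatter of compound 1.

Compound 3, `Cc1ccnc(/C(N)=N/NC(=S)N2CCCCCC2)c1`, keeps the seven-membered ring of compound 1 and differs from it only on the core: methyl in place of hydrogen on an aromatic carbon, the new group sitting on an aromatic carbon of the six-membered aromatic ring with one nitrogen, meta to a large group and opposite the ring nitrogen. Going by the values given here, no pair among the measured compounds shows the effect of such a change, so the expectation rests on compound 1 alone. A single methyl added to the core is expected to move the number no further than the scatter, in no fixed direction, so the estimated step of a number 1.7 percentage points higher from compound 1 to compound 3 (within the scatter) is small. Compound 3 is therefore expected to give about 27%, within a range from 12% to 45%.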

Compound 3, percent growth inhibition at one concentration: 18.2%
The estimate for compound 3 lay 8.8 percentage points above the measured number; the measured number falls inside the stated range.
By their numbers in this assay, from the lowest: compounds 2, 3 and 1 (each within the scatter of the next, the first and the last beyond it).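

In this assay, going by these compounds alone, the step is a number 7.1 percentage points lower from compound 1 to compound 3 (within the scatter) and gives the first reading of a change on the shared core, since the earlier comparison concerned only the ring on the thiourea nitrogen. It shows that, with the seven-membered ring kept, methyl in place of hydrogen on this aromatic carbon, meta to a large group and opposite the ring nitrogen, does not move the growth inhibition beyond the scatter at the single concentration tested. No measurement at hand bears on what lies behind the size of this step.

The compounds shown leave open whether a group other than methyl at this same place, such as an amine, a methoxy group, a carboxylic acid or a longer chain, would give a step beyond the scatter. They also leave open whether the same methyl would behave alike on the core of compound 2, which carries morpholine, or on another aromatic carbon of the core, and how any of these compounds would read at other concentrations.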